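Amino for chloro on a dichloropurine-derived core

The source may hold more compounds than are shown below. What is called first, only, known or untested is meant among the compounds shown, and "the series" means these compounds.

Measured so far:
compound 1 `ClCc1ccccc1Cn1cnc2c(Cl)nc(Cl)nc21` — in a functional assay on COLO 205 cells (Homo sapiens) for cytotoxicity, read by sulforhodamine B assay, with a stated time of 48 h (a lower number here means a stronger inhibitor of growth, a higher number a weaker inhibitor of growth), compound 1 gives "not determined" (no result reported).
compound 2 `ClCc1ccc(Cn2cnc3c(Cl)nc(Cl)nc32)cc1` — in this assay compound 2 gives > 100000 nM.

Two compounds share the same fused core and the same chloromethyl-bearing benzyl arm, differing only in where that arm is attached to its benzene ring. Compound 1 has no result of its own in this assay. For compound 2 the value is a limit of the assay, not a number: the limit of > 100000 nM in this assay, at which 1 of the 2 values shown sits. So compound 1 stands at no measured position; the only figure near it is this limit for compound 2.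

The next step keeps the arm of compound 1 and changes the core. In compound 3 `Nc1nc(Cl)c2ncn(Cc3ccccc3CCl)c2n1` the change is amino in place of chloro on an aromatic carbon. No measured step links two of these compounds, so the size of the change in this assay cannot be read from data; with compound 2 sitting at the limit, the expectation is for compound 3 to remain weak, and compound 3 is estimated at 80000 nM, between 10000 nM and 300000 nM.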

Compound 3, concentration for total growth inhibition: > 100000 nM
Compound 3: only a limit was reported; the forecaster's own chance of this, stated with the estimate: 55%; at least 1.2-fold (0.09 log units) between middle value and limit.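

In this assay compound 3 gives > 100000 nM, which is a limit of the assay and not a number. For the compounds shown here, compound 1 has no number to set against it, so no step from compound 1 to compound 3 can be read. The compounds shown leave open whether amino in place of chloro changes growth inhibition at all, and how strong any of them is: the limit of > 100000 nM in this assay, at which 2 of the 3 values shown sit.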